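The source may report more compounds than this note shows. Statements on the series, on what has been measured and on what is new or still open speak of the compounds shown alone.

Compound 1 `CC(C)c1cccc(C(C)C)c1NC(=O)NCC1(c2ccc(CC(C)(C)C)cc2)CCCC1` stands highest of the three numbers in an assay on microsomes for inhibition of acyl-CoA:cholesterol acyltransferase (Oryctolagus cuniculus) (a higher number here means a weaker inhibitor, a lower number a stronger inhibitor), at 159 nM. Compound 2 `COc1cccc(C2(CNC(=O)Nc3c(C(C)C)cccc3C(C)C)CCCC2)c1` gives 13 nM in this assay, and compound 3 `CC(C)c1cccc(C(C)C)c1NC(=O)NCC1(c2ccc(NCCO)cc2)CCCC1` gives 25 nM. Compound 4 `CC(C)c1cccc(C(C)C)c1NC(=O)NCC1(c2ccc(CO)cc2)CCCC1` differs from compound 1 by hydroxy in place of tert-butyl on a saturated chain carbon bound to an aromatic carbon. The step that bears most on this change is a 6.4-fold lower number from compound 1 to compound 3 (0.80 log units; beyond the scatter), which removes the same neopentyl group; a 12-fold lower number from compound 1 to compound 2 (1.09 log units; beyond the scatter) also removes it, to a different replacement. Both steps leave compound 1 with the highest number of the set. A lower number is therefore expected for compound 4, a step of a 4.5-fold lower number from compound 1 to compound 4 (0.66 log units; beyond the scatter). Compound 4 is estimated at 35 nM in this assay, within a range of 12 nM to 100 nM.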

Compound 4, half-maximal inhibitory concentration: 26 nM
Beside the measured number, compound 4's estimate is 1.3-fold (0.13 log units) above it; measured number inside the range.
By their numbers in this assay, from the lowest: compounds 2, 3 and 4 (each within the scatter of the next); then compound 1.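

In this assay, the change from neopentyl to hydroxymethyl brings a clear drop in the number (a 6.1-fold lower number from compound 1 to compound 4 (0.79 log units; beyond the scatter)). Hydroxymethyl and (2-hydroxyethyl)amino cannot be told apart (a 1.0-fold higher number from compound 3 to compound 4 (0.02 log units; within the scatter)), so the drop seen on leaving neopentyl does not depend on the amine nitrogen or the longer chain of compound 3. The 4-(hydroxymethyl)phenyl and 3-methoxyphenyl groups also stay within the scatter of each other (a 2.0-fold higher number from compound 2 to compound 4 (0.30 log units; within the scatter)).

No measurement shown accounts for the drop. Going by these compounds, whether the hydroxy matters or only the loss of neopentyl remains open; a plain methyl, a methoxymethyl or a carboxylic acid on that aromatic carbon would separate the two.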